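A Chain Amine Change Tested on a Second Core

The compounds below may be only part of what the source reports. "The series", "measured", "known", "first", "only" and "open" are said of these compounds alone.

In a functional assay on HeLa cells for agonist activity at 5-hydroxytryptamine receptor 6 (Homo sapiens), read by immunoassay (on this read-out higher numbers stand for larger maximal responses and lower numbers for smaller maximal responses), compound 2 `Cc1c(S(=O)(=O)c2ccccc2)c2cccnc2n1CCN(C)C` gives 100%, while compound 1 `Cc1c(S(=O)(=O)c2ccccc2)c2cccnc2n1CCN` gives 85%. The change between them is amino in place of dimethylamino on a saturated chain carbon, two bonds along the chain from an aromatic nitrogen, and it made the step of a number 15 percentage points lower from compound 2 to compound 1 (beyond the scatter). Compound 3 `CN(C)CCn1cc(S(=O)(=O)c2cc(Cl)cc(Cl)c2)c2cccnc21` rests on a different core; the difference between the two cores is not broken down here. In this assay compound 3 gives 80%. Compound 4 `NCCn1cc(S(=O)(=O)c2cc(Cl)cc(Cl)c2)c2cccnc21` has not been measured; it differs from compound 3 by amino in place of dimethylamino on a saturated chain carbon, two bonds along the chain from an aromatic nitrogen, the same change at the same place as before. Given the step of a number 15 percentage points lower from compound 2 to compound 1 (beyond the scatter), a step of similar size is expected for compound 4, namely a number 15 percentage points lower from compound 3 to compound 4 (beyond the scatter). In this assay compound 4 is therefore estimated at 65%, expected between 50% and 80%.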

Compound 4, largest response reached (Emax), in percent of the reference or control that the assay uses: 65%
Estimate against measurement, compound 4: no gap at the digits printed; low and high end bracket the measured number.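

On the core of compound 3, amino in place of dimethylamino gave in this assay a step of a number 15 percentage points lower from compound 3 to compound 4 (beyond the scatter), and set beside the earlier case, the change carried over from one core to the other at the same size: the same change on two cores in this assay, a number 15 percentage points lower (beyond the scatter) from compound 2 to compound 1 and a number 15 percentage points lower (beyond the scatter) from compound 3 to compound 4, 0 percentage points apart, within the scatter of two such steps

So, for these two pairs, the drop in maximal response did not depend on which of the two cores carried the chain. Two pairs do not make a rule, however, and they do not show that the step would hold on a further core or explain why it occurs.

The compounds shown leave open where a methylamino group would fall on this read-out. They also leave open how a pyrrolidine in place of the amine, or a longer chain, would behave on either core.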